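This account rests on a few compounds, and the source may have more. Where it says the series, first, only, none or still open, it means among the compounds named here.

The measured compounds:

Compound 1, `CCCOc1ccc(-c2cc(=O)c3c(o2)C(CC)(CC)C(=O)C(CC)=C3O)cc1`, gives 29.2 uM in a functional assay on KBVIN cells (Homo sapiens) for antiproliferative activity, read by sulforhodamine B assay, with a stated time of 3 days; a lower number here means that less compound is needed, a higher number that more compound is needed for the effect.
Compound 2, `CCC1=C(O)c2c(oc(-c3ccc(OC(F)(F)F)cc3)cc2=O)C(CC)(CC)C1=O`, gives 9.95 uM in this assay.
Compound 3, `CCC1=C(O)c2c(oc(-c3ccc(Br)cc3)cc2=O)C(CC)(CC)C1=O`, gives 15.7 uM in this assay.

Compound 3 sits second highest of the three numbers; its nearest neighbour is compound 2, with a 1.6-fold higher number from compound 2 to compound 3 (0.20 log units; within the scatter), and its furthest is compound 1, with a 1.9-fold lower number from compound 1 to compound 3 (0.27 log units; within the scatter), so all three numbers lie close together. Compound 4, `CCC1=C(O)c2c(oc(-c3ccc(C)cc3C)cc2=O)C(CC)(CC)C1=O`, has not yet been measured in this assay. It differs from compound 3 in one place: 2,4-dimethylphenyl in place of 4-bromophenyl on an aromatic carbon.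

All three measured steps exchange the group on the aromatic carbon next to the ring oxygen. The only one beyond the scatter is a 2.9-fold lower number from compound 1 to compound 2 (0.47 log units; beyond the scatter), a modest step; the other two stay within it. None of them puts a 2,4-dimethylphenyl in place, so they bear on the change only loosely, and the expected step of a 1.1-fold higher number from compound 3 to compound 4 (0.06 log units; within the scatter) is none beyond the scatter. Compound 4 is therefore estimated at 18 uM, with a range from 8 uM to 40 uM.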

Compound 4, concentration for half-maximal effect: 8.52 uM
The estimate for compound 4 lay 2.1-fold (0.32 log units) above the measured number, and the stated range covers the measured number.
By their numbers in this assay, from the lowest: compounds 4, 2, 3 and 1 (each within the scatter of the next, the first and the last beyond it).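

In this assay, putting 2,4-dimethylphenyl in place of 4-bromophenyl on the aromatic carbon next to the ring oxygen gives a 1.8-fold lower number from compound 3 to compound 4 (0.27 log units; within the scatter) and so no change that can be told apart from the scatter. Compounds 1, 2 and 3 each carry a single group on the phenyl ring, and that group holds oxygen or a halogen, whereas compound 4 shows that a ring bearing two methyl groups and no bromine can also sit here without leaving the range of compound 3. Nothing measured on these compounds explains this result.

How much each methyl group contributes alone remains open, since a phenyl ring with only one methyl is not among these compounds. Also open, on these data alone, is whether an amine or a carboxylic acid on that ring would move the number beyond the scatter.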